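The compounds below may be only part of what the source reports. "The series", "measured", "known", "first", "only" and "open" are said of these compounds alone.

Working notes on the series. Compound 1 `Cc1ccccc1OCC1=NCCO1`, compound 2 `Cc1cccc(OCC2=NCCO2)c1` and compound 3 `O=[N+]([O-])c1ccccc1OCC1=NCCO1` have been measured in a functional assay on the whole organism for inhibition, with Rattus norvegicus as the target, read by paw edema, with a stated time of 30 min, at a dose of 20 mg/kg by the oral route; on this read-out lower numbers stand for a weaker effect and higher numbers for a stronger effect at the one dose given; compound 4 `O=[N+]([O-])c1cccc(OCC2=NCCO2)c1` has not. In this assay compound 1 gives 3.1%, compound 2 gives 16.6% and compound 3 gives 20.5%. The difference between the core of compound 1 and the core of compound 2 is not broken down here; the two values show compound 2 above compound 1 by a margin beyond the scatter, while the values of compound 2 and compound 3 lie within the scatter of each other.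

One structural change recurs twice. From compound 1 to compound 3 the change is nitro in place of methyl on an aromatic carbon, and it made a step of a number 17.4 percentage points higher from compound 1 to compound 3 (beyond the scatter). From compound 2 to compound 4 the change is nitro in place of methyl on an aromatic carbon. The two are the same kind of change, not the same: in the first the place is ortho to a group of 7 heavy atoms, in the second it is meta to a group of 7 heavy atoms. For the measured compounds named here, no measured pair tests the change at the meta place, so the carry-over is unverified.

The step from compound 2 to compound 4 in this assay is expected to be a number 13.4 percentage points higher from compound 2 to compound 4 (beyond the scatter), set a little below the measured one because a number 17.4 percentage points higher from compound 1 to compound 3 (beyond the scatter) rests on a single pair at a different place. Compound 4 is accordingly estimated at 30% in this assay, with the expected range running from 14% to 46%.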

Compound 4, a percentage reported as inhibition, in the whole organism at one dose (the size of the read-out at that dose, not a potency): 15.5%
The estimate for compound 4 lay 14.5 percentage points above the measured number; measured number inside the range.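

In this assay, nitro in place of methyl on an aromatic carbon, meta to a group of 7 heavy atoms, makes a step of a number 1.1 percentage points lower from compound 2 to compound 4 (within the scatter), and this step differs from the one seen for the same kind of change on the other core: the same change on two cores in this assay, a number 17.4 percentage points higher (beyond the scatter) from compound 1 to compound 3 and a number 1.1 percentage points lower (within the scatter) from compound 2 to compound 4, 18.5 percentage points apart, beyond the scatter of two such steps The size of the step therefore does not carry over from the core of compound 1 to the core of compound 2, and a step read on one of these pairs is no guide to the other in this series. This does not show why the two steps differ or give any rule for the change in general: each step rests on a single pair, and the two pairs differ both in their core and in where the change sits, so the data cannot separate those two factors.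

The compounds shown leave open how an amine, a carboxylic acid or a longer chain in place of methyl or nitro would read out on either core. They also leave open whether nitro and methyl would compare in the same way at another dose or another time point.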